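The source may hold more compounds than are shown below. What is called first, only, known or untested is meant among the compounds shown, and "the series" means these compounds.

Every compound in this study was tested in an assay on HEK293 cells for agonist activity at Toll-like receptor 8 (Homo sapiens), read by spectrophotometry; on this read-out higher numbers stand for an effect only at larger amounts of compound and lower numbers for an effect already at smaller amounts. Three of them already have numbers. Compound 1, `CCCCNc1nc(N)nc(C)c1CCCn1c(C)nc2ccccc21`, gives 366 nM in this assay. Compound 3, `CCCCNc1nc(N)nc(C)c1CCCN1CCN(C(=O)OC(C)(C)C)CC1`, gives 300 nM. Compound 2, `C#Cc1c(C)nc(N)nc1NCCCC`, gives 4900 nM, which is the highest of the three numbers; the other two numbers lie lower by more than the usual scatter, so compound 2 is the one that needs the largest amount to show an effect.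

Compound 4, `CCCCNc1nc(N)nc(C)c1C#C[Si](C)(C)C`, shares the core of compound 2 and differs from it in one place: a group of 4 heavy atoms (3 carbon, 1 silicon; no ring) in place of a hydrogen atom, on a triple-bonded carbon. For the measured compounds named here, no measured pair of compounds shows this same change, so its effect is not known from the data. What the measured compounds do show is that compound 1 and compound 3, both carrying a larger group than the small triple-bonded group of compound 2, give lower numbers than compound 2. On that basis the change is expected to bring a moderate fall in the number, a 2.5-fold lower number from compound 2 to compound 4 (0.39 log units; beyond the scatter), though a flat outcome within the scatter cannot be ruled out. Compound 4 is therefore estimated to give 2000 nM in this assay, with a range from 600 nM to 6000 nM.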

Compound 4, half-maximal effective concentration: 9240 nM
Compound 4: middle estimate off by 4.6-fold (0.66 log units), on the low side; the measured number lies above the stated range.
By their numbers in this assay, from the lowest: compounds 3 and 1 (each within the scatter of the next); then compounds 2 and 4 (each within the scatter of the next).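

In this assay, putting the group of 4 heavy atoms (3 carbon, 1 silicon; no ring) in place of a hydrogen atom on the triple-bonded carbon gives a 1.9-fold higher number from compound 2 to compound 4 (0.28 log units; within the scatter) and so does not separate the two compounds. For the compounds shown here, this is the first direct reading at this place: the triple-bonded carbon can carry this much larger, silicon-containing group without a shift that stands out from the variation between repeated measurements. No measurement of any property or of binding accompanies this result, so the data offer no explanation of why the number stays within that variation.

On these data alone, one substituent says little about the place as a whole, so it remains open whether a different group on the triple-bonded carbon, such as a phenyl ring, a hydroxymethyl group or a chain ending in an amine, would move the number beyond the scatter. Also open, as far as these compounds go, is what the triple bond itself contributes, since compound 1 and compound 3 each differ from compound 2 in more than one place, and a plain ethyl group in its stead would be needed to isolate that.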